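The source may hold more compounds than are shown below. What is called first, only, known or untested is meant among the compounds shown, and "the series" means these compounds.

Measured so far in a functional assay on KARPAS-299 cells (Homo sapiens) for cytotoxicity, read by XTT assay, with a stated time of 72 h; on this read-out higher numbers stand for weaker inhibition and lower numbers for stronger inhibition:
compound 1 `Cn1cc(-c2cnc3[nH]cc(-c4cnn(Cc5cccc(C(=O)O)c5)c4)c3c2)cn1`: > 10000 nM, a limit of this assay
compound 2 `Cn1cc(-c2cnc3[nH]cc(-c4cnn(Cc5cccc(O)c5)c4)c3c2)cn1`: 3360 nM

For the measured compounds named here, compound 2 holds the only number in this assay; compound 1 sits at the limit (the limit of > 10000 nM in this assay, at which 1 of the 2 values shown sits). Going by the values given here, the single measured step, an at least 2.9-fold lower number from compound 1 to compound 2 (0.47 log units; beyond the scatter), is hydroxy in place of carboxy on an aromatic carbon. Compound 3 `Cn1cc(-c2cnc3[nH]cc(-c4cnn(Cc5ccc(F)c(F)c5)c4)c3c2)cn1` differs from compound 2 by 3,4-difluorophenyl in place of 3-hydroxyphenyl on a saturated chain carbon bound to an aromatic nitrogen. Among the compounds with values here, no measured step covers this exchange, and the step from compound 1 to compound 2 concerns a different group. The expected step is therefore a 1.1-fold lower number from compound 2 to compound 3 (0.05 log units; within the scatter), not beyond the scatter. Compound 3 is estimated at 3000 nM, between 800 nM and 12000 nM.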

Compound 3, half-maximal inhibitory concentration: 2260 nM
The estimate for compound 3 lay 1.3-fold (0.12 log units) above the measured number; the measured number falls inside the stated range.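

In this assay, the exchange on a saturated chain carbon bound to an aromatic nitrogen gives a 1.5-fold lower number from compound 2 to compound 3 (0.17 log units; within the scatter), so 3,4-difluorophenyl, with 0 hydrogen-bond donors, is not told apart from 3-hydroxyphenyl. Against the 3-carboxyphenyl of compound 1, the same exchange gives an at least 4.4-fold lower number from compound 1 to compound 3 (0.64 log units; beyond the scatter), so the carboxy compound stays apart from both neutral groups. Compound 1 is a limit, so this step is a bound and not a size: the limit of > 10000 nM in this assay, at which 1 of the 3 values shown sits.

Open, as far as these compounds go, is how an amine on the phenyl ring would read at this place. Also open, from the compounds shown here alone, is how a longer chain in place of the benzyl link would read.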